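Swapping the Amide Cap for a Phenylsulfonyl Group

The source may hold more compounds than are shown below. What is called first, only, known or untested is meant among the compounds shown, and "the series" means these compounds.

Of the compounds shown here, three sharing one core have been measured in an assay on isolated protein for displacement of a labelled ligand from secreted frizzled-related protein 1 (Homo sapiens), read by fluorescence polarization, with a stated time of 30 min; on this read-out lower numbers stand for stronger inhibition and higher numbers for weaker inhibition. Compound 1 `O=C(c1ccc(C(F)(F)F)cc1)N1CCC(NS(=O)(=O)c2cc(S(=O)(=O)c3ccccc3)ccc2C(F)(F)F)CC1` gives 400 nM. Compound 2 `O=C(c1cccnc1)N1CCC(NS(=O)(=O)c2cc(S(=O)(=O)c3ccccc3)ccc2C(F)(F)F)CC1` gives 80 nM, and compound 3 `CN(C)c1ccc(C(=O)N2CCC(NS(=O)(=O)c3cc(S(=O)(=O)c4ccccc4)ccc3C(F)(F)F)CC2)cn1` gives 40 nM. Compound 3 holds the lowest of the three numbers, but its gap to compound 2 lies within the scatter; only its gap to compound 1 is beyond it. The two steps that reach beyond the scatter, a 5.0-fold lower number from compound 1 to compound 2 (0.70 log units; beyond the scatter) and a 10-fold lower number from compound 1 to compound 3 (1.00 log units; beyond the scatter), both change the aryl group on the carbonyl carbon, while a 2.0-fold lower number from compound 2 to compound 3 (0.30 log units; within the scatter) adds only a dimethylamino group and stays within the scatter.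

Compound 4 `O=S(=O)(NC1CCN(S(=O)(=O)c2ccccc2)CC1)c1cc(S(=O)(=O)c2ccccc2)ccc1C(F)(F)F` differs from compound 3 in a different way: phenylsulfonyl in place of (6-(dimethylamino)pyridin-3-yl)carbonyl on an amine nitrogen in a ring. Among the compounds with values here, no measured step alters the carbonyl itself, so none bears directly on this change. The nearest guide is that a carbon-only ring on the carbonyl carbon, as in compound 1 with 400 nM, gave the highest number seen. Compound 4 is therefore expected to show a higher number, with a 7.5-fold higher number from compound 3 to compound 4 (0.88 log units; beyond the scatter) as the estimated step. The estimate for compound 4 is 300 nM, within a range from 80 nM to 1200 nM.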

Compound 4, half-maximal inhibitory concentration: 130 nM
Compound 4: the middle estimate sits 2.3-fold (0.36 log units) above what was measured, within the range that was stated.
By their numbers in this assay, from the lowest: compounds 3, 2 and 4 (each within the scatter of the next, the first and the last beyond it); then compound 1.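

The earlier compounds shown here tied the lower numbers to pyridine rings on the carbonyl, but compound 4 shows that a carbon-only ring on this amine nitrogen need not stay with compound 1: the change gives a 3.1-fold lower number from compound 1 to compound 4 (0.49 log units; beyond the scatter). Against the plain pyridine amide, phenylsulfonyl costs nothing that can be told apart, with a 1.6-fold higher number from compound 2 to compound 4 (0.21 log units; within the scatter), whereas against the dimethylamino-bearing amide there is a real loss, with a 3.3-fold higher number from compound 3 to compound 4 (0.51 log units; beyond the scatter). No measurement here explains either shift.

The compounds shown leave open whether the gain over compound 1 follows the sulfonyl link or the loss of the trifluoromethyl group, and a plain benzoyl group on the same nitrogen would separate the two. A pyridin-3-ylsulfonyl group there would show whether the pyridine ring and the sulfonyl link can be combined.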